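Halogen swap on the anilide ring of compound 2

This account rests on a few compounds, and the source may have more. Where it says the series, first, only, none or still open, it means among the compounds named here.

compound 1, `Cc1ccc(NC(=O)CN2CCN(S(=O)(=O)N3CCC(C)CC3)CC2)cc1`, in an assay on HEK293 cells for activation of potassium channel subfamily T member 1 (Homo sapiens), read by thallium flux; on this read-out higher numbers stand for an effect only at larger amounts of compound and lower numbers for an effect already at smaller amounts: 4100 nM
compound 2, `CC1CCN(S(=O)(=O)N2CCN(CC(=O)Nc3cccc(Cl)c3)CC2)CC1`, in this assay: 7600 nM
compound 3, `COc1ccc(Cl)cc1NC(=O)N1CCC2(CC1)CN(S(=O)(=O)N1CCC(C)CC1)C2`, in this assay: 10000 nM

Within the data shown here, compound 2 holds the second highest of the three numbers; compound 3 gives 10000 nM and compound 2 gives 7600 nM, and the one step that reaches compound 2, a 1.9-fold higher number from compound 1 to compound 2 (0.27 log units; within the scatter), is within the scatter. Compound 4, `CC1CCN(S(=O)(=O)N2CCN(CC(=O)Nc3cccc(F)c3)CC2)CC1`, differs from compound 2 by fluoro in place of chloro on an aromatic carbon. Among the measured compounds shown here, no measured step exchanges one halogen for another on this ring; the only aryl change seen, from compound 1 to compound 2, is a different substituent at a different place and stays within the scatter. No step beyond the scatter is therefore expected, a 1.1-fold higher number from compound 2 to compound 4 (0.02 log units; within the scatter). Compound 4 is estimated at 8000 nM, between 3500 nM and 18000 nM.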

Compound 4, half-maximal effective concentration: 4600 nM
Compound 4: middle estimate off by 1.7-fold (0.24 log units), on the high side, within the range that was stated.
By their numbers in this assay, from the lowest: compounds 1, 4, 2 and 3 (each within the scatter of the next, the first and the last beyond it).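

Within this assay this is the only halogen exchange shown at this place: fluoro in place of chloro leaves the number within the scatter (a 1.7-fold lower number from compound 2 to compound 4 (0.22 log units; within the scatter)). The 3-fluorophenyl and 4-methylphenyl groups are also not separated (a 1.1-fold higher number from compound 1 to compound 4 (0.05 log units; within the scatter)), so the three aryl groups on the amide-type nitrogen show no difference in this read-out. No evidence on a cause accompanies this result.

From the compounds shown here alone, whether an amine or a carboxylic acid in place of the halogen would give a step beyond the scatter stays open. So does the effect of the same fluoro exchange on the 4-methylphenyl ring.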